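Pyrrolidinyl Amide Replaced by a 4-Aminocyclohexyl Amide

The source may report more compounds than this note shows. Statements on the series, on what has been measured and on what is new or still open speak of the compounds shown alone.

Measured compounds:
Compound 1, `O=C(Nc1cc2cc[nH]c(=O)c2cc1Cl)[C@H]1CCCN1`: 130 nM
Compound 2, `CC(C)N[C@H](C(=O)Nc1cc2cc[nH]c(=O)c2cc1Cl)C1CCCCC1`: 25 nM

Both compounds were measured in an assay on isolated protein for inhibition of Rho-associated protein kinase 2 (Homo sapiens); on this read-out higher numbers stand for weaker inhibition and lower numbers for stronger inhibition. Compound 1 has the highest of the two numbers; compound 2 gives a lower number, and that gap lies beyond the scatter. Compound 3, `N[C@H]1CC[C@@H](C(=O)Nc2cc3cc[nH]c(=O)c3cc2Cl)CC1`, differs from compound 1 in one place: 4-aminocyclohexyl in place of pyrrolidin-2-yl on a carbonyl carbon. Among the measured compounds shown here, no step between measured compounds isolates this change, so any expectation rests on the two values alone. Compound 3 is expected to give a somewhat lower number, a step of a 2.2-fold lower number from compound 1 to compound 3 (0.34 log units; beyond the scatter) of modest size. The estimate for compound 3 is 60 nM, with a range from 15 nM to 250 nM.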

Compound 3, half-maximal inhibitory concentration: 15 nM
Compound 3: the middle estimate sits 4.0-fold (0.60 log units) above what was measured; low and high end bracket the measured number.
By their numbers in this assay, from the lowest: compounds 3 and 2 (each within the scatter of the next); then compound 1.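

In this assay the change to 4-aminocyclohexyl on the carbonyl carbon brings an 8.7-fold lower number from compound 1 to compound 3 (0.94 log units; beyond the scatter), so at this position the pyrrolidin-2-yl ring is not required for a low number. A six-membered ring of carbon only that carries an amine serves here, and the entering group is the larger by heavy atom count. Nothing available accounts for the size of this step.

As far as these compounds go, whether the amine itself matters remains open, since a plain cyclohexyl or a hydroxyl in its place would be needed to tell. From the compounds shown here alone, the role of the arrangement at the two defined stereocentres of compound 3 also remains open.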